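Moving a nitrile around the benzyl ring

The source may hold more compounds than are shown below. What is called first, only, known or untested is meant among the compounds shown, and "the series" means these compounds.

Measured so far in a functional assay on a cell-free system (plasma, Oryctolagus cuniculus) for inhibition, with stated times of 5 min, 1 min and 6 min; a higher number here means a weaker inhibitor, a lower number a stronger inhibitor
- compound 1 `CCOC(=O)c1c(C)nc(-c2cccc(C#N)c2)n1O` gives 17600 nM
- compound 2 `CCOC(=O)c1c(C)nc(-c2cccc(C#N)c2)n1OCc1ccc(Cl)cc1` gives 6830 nM
- compound 3 `CCOC(=O)c1c(C)nc(-c2cccc(C#N)c2)n1OCc1ccc(C#N)cc1` gives 4240 nM

Compound 3 stands with compound 2 at the lower end of these numbers, clear of compound 1. Adding a substituted benzyl group to compound 1 gave modest gains, seen as a 2.6-fold lower number from compound 1 to compound 2 (0.41 log units; beyond the scatter) and a 4.2-fold lower number from compound 1 to compound 3 (0.62 log units; beyond the scatter). Compound 4 `CCOC(=O)c1c(C)nc(-c2cccc(C#N)c2)n1OCc1ccccc1C#N` has the same atoms as compound 3, joined differently: 2-cyanophenyl in place of 4-cyanophenyl on a saturated chain carbon bound to an oxygen on an aromatic ring. Among the measured compounds shown here, no measured step moves a nitrile around this ring. The nearest guide is the change of group on that ring, a 1.6-fold lower number from compound 2 to compound 3 (0.21 log units; within the scatter), so no step beyond the scatter is expected in this assay. The estimate means a 1.1-fold higher number from compound 3 to compound 4 (0.05 log units; within the scatter). For compound 4 the estimated value is 4800 nM, with an expected range of 2000 nM to 11000 nM.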

Compound 4, half-maximal inhibitory concentration: 9380 nM
Beside the measured number, compound 4's estimate is 2.0-fold (0.29 log units) below it; the range from low to high includes it.
By their numbers in this assay, from the lowest: compounds 3, 2, 4 and 1 (each within the scatter of the next, the first and the last beyond it).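

In this assay, among the compounds shown here, the place of the nitrile on the benzyl ring counts: going from 4-cyanobenzyl to 2-cyanobenzyl gives a 2.2-fold higher number from compound 3 to compound 4 (0.34 log units; beyond the scatter) as the only change, a shift the earlier compounds could not show. Compound 4 stays within the scatter of both neighbours, with a 1.4-fold higher number from compound 2 to compound 4 (0.14 log units; within the scatter) and with a 1.9-fold lower number from compound 1 to compound 4 (0.27 log units; within the scatter) so 2-cyanobenzyl does not hold a clear gain over hydrogen as 4-cyanobenzyl does. No measurement here gives a reason for this shift.

Still open, going by these compounds, is how an unsubstituted benzyl group or a longer chain on that oxygen would compare.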